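Anilide in place of the thiophene methylamide

The compounds below may be only part of what the source reports. "The series", "measured", "known", "first", "only" and "open" are said of these compounds alone.

Of the compounds shown here, three sharing one core have been measured in a functional assay on MDA-MB-435 cells (Homo sapiens) for cytotoxicity, read by MTT assay, with a stated time of 72 h; on this read-out lower numbers stand for stronger inhibition and higher numbers for weaker inhibition. Compound 1 `N[C@H]1CC[C@H](Nc2c(C(=O)NCc3ccc(Cl)cc3)nc(Br)c3cccnc23)CC1` gives 1000 nM. Compound 2 `COC(=O)c1nc(Br)c2cccnc2c1N[C@H]1CC[C@H](N)CC1`, in which a methoxy replaces the (4-chlorobenzyl)amino group on the carbonyl carbon, reaches only the limit of the assay at > 20000 nM, a limit rather than a number. Compound 3 `N[C@H]1CC[C@H](Nc2c(C(=O)NCc3cccs3)nc(Br)c3cccnc23)CC1` gives 4100 nM, the highest of the two numbers; its nearest neighbour is compound 1, reached by a 4.1-fold higher number from compound 1 to compound 3 (0.61 log units; beyond the scatter). Against compound 2 it shows an at least 4.8-fold lower number from compound 2 to compound 3 (0.68 log units; beyond the scatter), and compound 1 shows an at least 20-fold higher number from compound 1 to compound 2 (1.30 log units; beyond the scatter), both marked by the limit of > 20000 nM in this assay, at which 1 of the 3 values shown sits.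

Compound 4 `N[C@H]1CC[C@H](Nc2c(C(=O)Nc3ccccc3)nc(Br)c3cccnc23)CC1` keeps the amide-type nitrogen of compound 3 but carries phenyl in place of (thiophen-2-yl)methyl on an amide-type nitrogen. The measured steps show that the group on this nitrogen changes the read-out by a modest amount, while removing the amide altogether costs far more. A modest step, in either direction, is therefore expected for compound 4 in this assay, written as a 1.2-fold higher number from compound 3 to compound 4 (0.09 log units; within the scatter). Compound 4 is estimated at 5000 nM, with a range from 1500 nM to 16000 nM.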

Compound 4, half-maximal inhibitory concentration: 1000 nM
The estimate for compound 4 lay 5.0-fold (0.70 log units) above the measured number; the measured number lies below the stated range.
By their numbers in this assay, from the lowest: compounds 1 and 4 (each within the scatter of the next); then compound 3. At a limit, above all of these: compound 2.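

In this assay, the group on the amide-type nitrogen can carry an aromatic ring with no saturated chain carbon in between: phenyl in place of (thiophen-2-yl)methyl gives a 4.1-fold lower number from compound 3 to compound 4 (0.61 log units; beyond the scatter), and phenyl in place of 4-chlorobenzyl gives no change at the digits printed from compound 1 to compound 4 (within the scatter), so the chain carbon and the chlorine together leave no readable mark on this read-out. The anilino group also keeps the large distance from the methoxy of the earlier comparison, with an at least 20-fold lower number from compound 2 to compound 4 (1.30 log units; beyond the scatter). Compound 2 carries a limit rather than a number, so that step gives only a minimum size: the limit of > 20000 nM in this assay, at which 1 of the 4 values shown sits.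

Compound 1 and compound 4 differ in both the chlorine and the chain carbon, so the shown compounds cannot tell whether each change is silent on its own or whether the two happen to cancel. An unsubstituted benzyl or a 4-chlorophenyl on the same nitrogen would separate the two changes, and a (thiophen-2-yl) group placed directly on that nitrogen would show whether the weaker number of compound 3 goes with its ring or with its chain.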